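Tertiary alkylamino replacement on the aminopyridine core

The compounds below may be only part of what the source reports. "The series", "measured", "known", "first", "only" and "open" are said of these compounds alone.

Compound 1 `CC1CCC(Nc2nc(C(F)(F)F)ccc2CNC(=O)C(C)c2ccc(NS(C)(=O)=O)c(F)c2)CC1`: 27.2 nM
Compound 2 `CC(C(=O)NCc1ccc(C(F)(F)F)nc1Nc1ccccc1)c1ccc(NS(C)(=O)=O)c(F)c1`: 59.6 nM
Compound 3 `CC(C(=O)NCc1ccc(C(F)(F)F)nc1NCc1cccnc1)c1ccc(NS(C)(=O)=O)c(F)c1`: "not active" (no number reported)

All three were tested in a functional assay on CHO-K1 cells for antagonist activity at transient receptor potential cation channel subfamily V member 1 (Homo sapiens), read by FLIPR; a higher number here means a weaker inhibitor, a lower number a stronger inhibitor. Going by the values given here, compound 1 gives 27.2 nM and compound 2 gives 59.6 nM; the single measured step, a 2.2-fold higher number from compound 1 to compound 2 (0.34 log units; beyond the scatter), is modest. Compound 3 stands apart: in this assay compound 3 is recorded as "not active" (no number reported), with no number reported, so it has no place on the scale the other two define.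

Compound 4 `CCCCN(C)c1nc(C(F)(F)F)ccc1CNC(=O)C(C)c1ccc(NS(C)(=O)=O)c(F)c1` differs from compound 3 by butyl(methyl)amino in place of ((pyridin-3-yl)methyl)amino on an aromatic carbon. Among the compounds with values here, no measured step bears directly on this change: the only step available swaps one ring-bearing amino group for another while keeping the hydrogen-bond donor, whereas here the ring is removed and the donor is lost. With compound 3 giving no number, the direction of the step cannot be read from the data; the outcome of compound 4 is therefore uncertain in this assay, and a further inactive result is a real possibility.

For compound 4 in this assay a value of about 400 nM is expected, within a range of 60 nM to 4000 nM.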

Compound 4, inhibition constant: 0.8 nM
Compound 4: middle estimate off by 500-fold (2.70 log units), on the high side; measured number outside the range, below it.
By their numbers in this assay, from the lowest: compound 4; then compound 1; then compound 2.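

On an aromatic carbon next to the ring nitrogen, butyl(methyl)amino gives the lowest number among the compounds with a value in this assay, with a 75-fold lower number from compound 2 to compound 4 (1.87 log units; beyond the scatter) and a 34-fold lower number from compound 1 to compound 4 (1.53 log units; beyond the scatter), both well beyond the earlier 2.2-fold higher number from compound 1 to compound 2 (0.34 log units; beyond the scatter). This position therefore tolerates a group with no ring and no hydrogen-bond donor, so the amino hydrogen kept in compound 1 and compound 2 is not required for a low number. The step from compound 3 to compound 4 cannot be read, as compound 3 has no number.

Nothing measured here accounts for the size of these steps. Open, as far as these compounds go, is whether butylamino or a shorter chain such as ethyl(methyl)amino would keep the number of compound 4 , which would separate the contribution of the butyl chain from that of the methyl on nitrogen.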